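Compound 2 to compound 3: an aryl group exchange

The compounds below may be only part of what the source reports. "The series", "measured", "known", "first", "only" and "open" are said of these compounds alone.

In a functional assay on HL-60 cells (Homo sapiens) for cytotoxicity, read by WST assay, with a stated time of 48 h (a higher number here means that more compound is needed for the effect, a lower number that less compound is needed), compound 1 (`O=C1OC[C@H](Cc2ccccc2)[C@H]1Cc1cc(Cl)cc(Cl)c1`) gives 23000 nM and compound 2 (`COc1ccccc1C[C@H]1COC(=O)[C@@H]1Cc1ccc(Cl)c(Cl)c1`) gives 14000 nM. These two values lie within the usual scatter of each other, so compound 2 cannot be separated from compound 1. Compound 3 (`O=C1OC[C@H](Cc2ccc(O)cc2)[C@H]1Cc1ccc(Cl)c(Cl)c1`) has 4-hydroxyphenyl in place of 2-methoxyphenyl on a saturated chain carbon bound to a saturated ring carbon. For the measured compounds named here, no measured pair shows this exchange. In this assay the expected step of a 1.1-fold lower number from compound 2 to compound 3 (0.03 log units; within the scatter) stays within the scatter, with no direction expected. The estimate for compound 3 is 13000 nM (range 5000 nM to 35000 nM).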

Compound 3, half-maximal effective concentration: 37000 nM
Compound 3: middle estimate off by 2.8-fold (0.45 log units), on the low side, outside the stated range (above it).
By their numbers in this assay, from the lowest: compounds 2, 1 and 3 (each within the scatter of the next, the first and the last beyond it).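

In this assay, for the compounds shown here, the exchange gives a 2.6-fold higher number from compound 2 to compound 3 (0.42 log units; beyond the scatter) as the only step so far, modest but beyond the scatter. This position on the shared core therefore responds to the aryl group it carries, and 4-hydroxyphenyl needs more compound than 2-methoxyphenyl. Nothing available gives a reason for this step.

The exchange alters both the substituent and its place on the ring, so the two contributions remain unseparated. A 4-methoxyphenyl or 2-hydroxyphenyl group would divide them, while a 4-aminophenyl group would test another substituent at this place.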